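Same swap, two cores: expecting cytotoxicity of compound 4

A few compounds are considered here, and "the series" means these few. Any claim that something is new, unique, unknown or untested is made for them only; others in the source may bear on it.

Measured so far:
- compound 1 `COc1cc(/C=C2\CN(S(=O)(=O)c3ccc(F)cc3)C/C(=C\c3cccc([N+](=O)[O-])c3)C2=O)cc(OC)c1OC`: 18800 nM
- compound 2 `COc1cc(/C=C2\CN(S(=O)(=O)c3ccc(F)cc3)C/C(=C\c3ccc(C#N)cc3)C2=O)cc(OC)c1OC`: 12900 nM
- compound 3 `CC(=O)Nc1ccc(S(=O)(=O)N2C/C(=C\c3cccc([N+](=O)[O-])c3)C(=O)/C(=C/c3ccccc3F)C2)cc1`: 18400 nM

In an ADME assay on L02 cells (Homo sapiens) for cytotoxicity, read by MTT assay, with a stated time of 24 h (on this read-out higher numbers stand for weaker inhibition and lower numbers for stronger inhibition), compound 1 gives 18800 nM and compound 2 gives 12900 nM. The change between them is 4-cyanophenyl in place of 3-nitrophenyl on a double-bonded chain carbon bound to a double-bonded ring carbon, and it made a step of a 1.5-fold lower number from compound 1 to compound 2 (0.16 log units; within the scatter). Compound 3, with its own core, gives 18400 nM in this assay; how the core of compound 3 differs from the core of compound 1 is not broken down here.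

Compound 4 `CC(=O)Nc1ccc(S(=O)(=O)N2C/C(=C\c3ccc(C#N)cc3)C(=O)/C(=C/c3ccccc3F)C2)cc1` is not yet measured. Within the data shown here, it differs from compound 3 by 4-cyanophenyl in place of 3-nitrophenyl on a double-bonded chain carbon bound to a double-bonded ring carbon, which is the same change, at the same kind of place, as the one from compound 1 to compound 2. Because the earlier step was a 1.5-fold lower number from compound 1 to compound 2 (0.16 log units; within the scatter), the step from compound 3 to compound 4 is expected to be of similar size, a 1.5-fold lower number from compound 3 to compound 4 (0.17 log units; within the scatter), though one prior example is a thin basis. Compound 4 is therefore estimated at 12500 nM in this assay, with a plausible range from 7000 nM to 25000 nM.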

Compound 4, half-maximal inhibitory concentration: 14400 nM
Estimate against measurement, compound 4: 1.2-fold (0.06 log units) below; low and high end bracket the measured number.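

In this assay, putting 4-cyanophenyl in place of 3-nitrophenyl on a double-bonded chain carbon bound to a double-bonded ring carbon gives a 1.3-fold lower number from compound 3 to compound 4 (0.11 log units; within the scatter), so on this second core the swap again produces a step that cannot be told apart from repeat-measurement scatter. Setting this step beside the earlier one shows that the two cores agree: the same change on two cores in this assay, a 1.5-fold lower number (0.16 log units; within the scatter) from compound 1 to compound 2 and a 1.3-fold lower number (0.11 log units; within the scatter) from compound 3 to compound 4, 1.1-fold (0.06 log units) apart, within the scatter of two such steps Within these four compounds, then, the swap carries from one core to the other as a step too small to read, but this does not show that the swap has any real effect on the number, and two pairs make no rule for other cores.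

The compounds shown hold only 3-nitrophenyl and 4-cyanophenyl at this place, so it stays open whether a phenyl ring carrying an amine or a carboxylic acid would give a step beyond the scatter. Going by these compounds, it also stays open whether the same swap would remain this small on a third core.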